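This account rests on a few compounds, and the source may have more. Where it says the series, first, only, none or still open, it means among the compounds named here.

Measured in a functional assay on B16-F10 cells (Mus musculus) for antiproliferative activity, read by MTT assay, with a stated time of 48 h; on this read-out higher numbers stand for weaker inhibition and lower numbers for stronger inhibition:
- compound 1 `COc1ccc(/C=C/c2cc(OC)cc(OC)c2/C=C/C(=O)c2ccc(C)cc2)cc1`: 5.3 ug/mL
- compound 2 `CCCCOc1ccc(C(=O)/C=C/c2c(/C=C/c3ccc(OC)cc3)cc(OC)cc2OC)cc1`: 5.3 ug/mL
- compound 3 `COc1ccc(/C=C/c2cc(OC)cc(OC)c2/C=C/C(=O)c2ccc(N)cc2)cc1`: 2.8 ug/mL

Compound 3, at 2.8 ug/mL, cannot be separated from the other two members, as a 1.9-fold lower number from compound 1 to compound 3 (0.28 log units; within the scatter) and a 1.9-fold lower number from compound 2 to compound 3 (0.28 log units; within the scatter) show. So far, the series offers no measured step beyond the scatter.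

Next is compound 4 `COc1ccc(/C=C/c2cc(OC)cc(OC)c2/C=C/C(=O)c2ccc(Cl)cc2)cc1`, which has chloro in place of amino on an aromatic carbon. Within the data shown here, no chloro compound has been measured, so the estimate rests on the other substituents at this place. Removing amino has been tested twice, in the reverse direction of the two steps above, and neither step leaves the scatter. The two compounds without amino also match each other, with no change at the digits printed from compound 1 to compound 2 (within the scatter).

No step beyond the scatter is therefore expected in this assay. If there is any drift, the number should move slightly upward, toward those of compound 1 and compound 2. The estimated step is a 1.6-fold higher number from compound 3 to compound 4 (0.21 log units; within the scatter). Compound 4 is expected at 4.5 ug/mL, with an estimated range of 2.2 ug/mL to 9 ug/mL.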

Compound 4, half-maximal inhibitory concentration: 4.9 ug/mL
Compound 4: the middle estimate sits 1.1-fold (0.04 log units) below what was measured; low and high end bracket the measured number.
By their numbers in this assay, from the lowest: compounds 3, 4, 1 and 2 (each within the scatter of the next).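

With chloro, the only halogen shown at this place, on an aromatic carbon para to a large group, this assay gives a 1.8-fold higher number from compound 3 to compound 4 (0.24 log units; within the scatter) and so the exchange of amino, with its hydrogen-bond donor and acceptor, for chloro, with neither, still leaves no step beyond the scatter. Chloro also cannot be separated from the two other groups without amino, as a 1.1-fold lower number from compound 1 to compound 4 (0.03 log units; within the scatter) for methyl and a 1.1-fold lower number from compound 2 to compound 4 (0.03 log units; within the scatter) for butoxy show, and all four groups at this place now lie within the scatter of one another, whether the entering group is a single atom or a chain. No measurement on these compounds accounts for this flat picture.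

From the compounds shown here alone, whether any group at this place can produce a step beyond the scatter remains open, and a carboxylic acid, a nitrile or a chain longer than butoxy would probe that further. The compounds shown vary this one place only, so they leave open how the rest of the shared core bears on the numbers in this assay and whether the same flat picture would hold with other changes there.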